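Swapping a chlorophenyl for naphthyl on the thioether arm

A few compounds are considered here, and "the series" means these few. Any claim that something is new, unique, unknown or untested is made for them only; others in the source may bear on it.

Compound 1 `Cc1cc(S(=O)(=O)/N=C(\N)n2nccc2-c2ccccc2)c(SCc2cccc(Cl)c2)cc1Cl` is the reference here. Within the data shown here, in a functional assay on HCT-116 cells (Homo sapiens) for cytotoxicity, read by MTT assay, with a stated time of 72 h (a lower number here means a stronger inhibitor, a higher number a weaker inhibitor), compound 1 gives 7000 nM, the lowest of the two numbers known. Compound 2 `Cc1cc(-c2ccccc2)n(/C(N)=N/S(=O)(=O)c2cc(C)c(Cl)cc2SCc2cccc(Cl)c2)n1` gives 18000 nM, and the step of a 2.6-fold higher number from compound 1 to compound 2 (0.41 log units; beyond the scatter) comes from a methyl in place of hydrogen on an aromatic carbon. Compound 3 `Cc1cc(S(=O)(=O)/N=C(\N)n2nccc2-c2ccccc2)c(SCc2cccc3ccccc23)cc1Cl` differs from compound 1 by naphthalen-1-yl in place of 3-chlorophenyl on a saturated chain carbon bound to a sulfur. Among the measured compounds shown here, no measured step touches this part of the molecule, so the only guide is the scale of the one step seen. The expected change is no change at the digits printed from compound 1 to compound 3 (within the scatter), small and uncertain in direction. Compound 3 is therefore estimated at 7000 nM, within 2500 nM to 20000 nM.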

Compound 3, half-maximal inhibitory concentration: 7000 nM
Compound 3: middle estimate and measured number agree at the digits printed, and the stated range covers the measured number.
By their numbers in this assay, from the lowest: compounds 1 and 3 (each within the scatter of the next); then compound 2.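

Placing naphthalen-1-yl in place of 3-chlorophenyl on the saturated chain carbon bound to a sulfur gives no change at the digits printed from compound 1 to compound 3 (within the scatter) in this assay. This position can therefore carry 2 six-membered aromatic rings and no chlorine, rather than one ring with chlorine, and the number stays within the scatter. No measured evidence bears on why this is so. Still open, on these data alone, is whether a carboxylic acid or an amine on this arm, or a saturated cyclohexyl ring in place of the aromatic group, would give a similar number.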